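Swapping Ethynyl for Furan-2-yl on a Nucleoside Core

The compounds below may be only part of what the source reports. "The series", "measured", "known", "first", "only" and "open" are said of these compounds alone.

Measured so far:
compound 1, `C#Cc1cn([C@@H]2O[C@H](CO)[C@@H](O)[C@H]2O)c2nc(N)nc(OC)c12`: > 20000 nM
compound 2, `C#Cc1cn([C@@H]2O[C@H](CO)[C@@H](O)[C@H]2O)c2ncnc(OC)c12`: 4060 nM
compound 3, `C#Cc1cn([C@@H]2O[C@H](CO)[C@@H](O)[C@H]2O)c2ncnc(SC)c12`: 30 nM

These three compounds share a core and were tested in a functional assay on HCT-116 cells (Homo sapiens), read by MTT assay, with a stated time of 72 h; a higher number here means a weaker inhibitor, a lower number a stronger inhibitor. For compound 1 the reading is a limit of the assay rather than a number: the limit of > 20000 nM in this assay, at which 1 of the 3 values shown sits. Compound 2 gives 4060 nM in this assay, which is the highest of the two numbers shown. Compound 3 sits far below it, a step of a 140-fold lower number from compound 2 to compound 3 (2.13 log units; beyond the scatter). The other measured step, an at least 4.9-fold lower number from compound 1 to compound 2 (0.69 log units; beyond the scatter), concerns the amino group.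

Compound 4, `COc1ncnc2c1c(-c1ccco1)cn2[C@@H]1O[C@H](CO)[C@@H](O)[C@H]1O`, differs from compound 2 by furan-2-yl in place of ethynyl on an aromatic carbon. Neither measured step touches this position: one changes amino to hydrogen, the other methoxy to methylsulfanyl. The data therefore give no direct guide to this change, and the expectation is a step of no clear direction, with wide uncertainty around the value of compound 2. Compound 4 is expected to give 2500 nM, within 300 nM to 15000 nM. This estimate means an expected 1.6-fold lower number from compound 2 to compound 4 (0.21 log units; within the scatter).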

Compound 4, half-maximal inhibitory concentration: 40 nM
The estimate for compound 4 lay 63-fold (1.80 log units) above the measured number; measured number below the stated range.
By their numbers in this assay, from the lowest: compounds 3 and 4 (each within the scatter of the next); then compound 2. At a limit, above all of these: compound 1.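

For the compounds shown here, the position on the aromatic carbon that carried ethynyl turns out to be highly sensitive in this assay, which the earlier steps could not reveal because they changed only the amino and methoxy groups. Replacing the small ethynyl with the larger furan-2-yl ring gives a 100-fold lower number from compound 2 to compound 4 (2.01 log units; beyond the scatter), so ethynyl is not required here for a low number, and a five-membered aromatic ring is accepted at this position. This makes a second large step away from compound 2, alongside a 140-fold lower number from compound 2 to compound 3 (2.13 log units; beyond the scatter), but nothing measured here explains why either change has such a large effect.

Still open, as far as these compounds go, is whether phenyl, thiophen-2-yl or a longer chain such as propyl would behave like furan-2-yl at this position. Also open, from the compounds shown here alone, is how furan-2-yl would combine with methylsulfanyl on the shared core.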